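The source may hold more compounds than are shown below. What is called first, only, known or untested is meant among the compounds shown, and "the series" means these compounds.

Measured compounds:
Compound 1 `CN(Cc1nc[nH]n1)[C@H](COCc1cc(C(F)(F)F)cc(C(F)(F)F)c1)c1ccccc1` — 1.4 nM in an assay on CHO cells for displacement of a labelled ligand from Substance-P receptor (Homo sapiens); a higher number here means a weaker inhibitor, a lower number a stronger inhibitor
Compound 2 `CN(Cc1nn[nH]n1)[C@H](COCc1cc(C(F)(F)F)cc(C(F)(F)F)c1)c1ccccc1` — 70 nM in this assay

Compound 2 stands highest of the two numbers; its nearest neighbour is compound 1, and the step of a 50-fold higher number from compound 1 to compound 2 (1.70 log units; beyond the scatter) separates them. Compound 3 `Cn1nnnc1CN[C@H](COCc1cc(C(F)(F)F)cc(C(F)(F)F)c1)c1ccccc1` differs from compound 2 in this way: ((1-methyl-1H-tetrazol-5-yl)methyl)amino in place of ((2H-tetrazol-5-yl)methyl)(methyl)amino on a saturated chain carbon bound to an aromatic carbon and a saturated chain carbon. The two compounds have the same atoms joined differently, with the methyl moved from the amine nitrogen onto the tetrazole ring.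

Among the measured compounds shown here, the only measured step, a 50-fold higher number from compound 1 to compound 2 (1.70 log units; beyond the scatter), concerns the exchange of one five-membered ring for another and not the placement of a methyl; no measured pair shows a shift of the methyl between these positions. The step from compound 2 to compound 3 is therefore expected to be modest, with its direction uncertain, and the estimated step is no change at the digits printed from compound 2 to compound 3 (within the scatter). For compound 3 in this assay the expected value is 70 nM, within a range from 15 nM to 350 nM.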

Compound 3, half-maximal inhibitory concentration: 10 nM
Estimate against measurement, compound 3: 7.0-fold (0.85 log units) above; the measured number lies below the stated range.
By their numbers in this assay, from the lowest: compound 1; then compound 3; then compound 2.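

In this assay, moving the methyl from the amine nitrogen onto the tetrazole ring gives a 7.0-fold lower number from compound 2 to compound 3 (0.85 log units; beyond the scatter) and shows that this position responds to where the methyl sits, not only to which five-membered ring is present. The ((1-methyl-1H-tetrazol-5-yl)methyl)amino group still does not match the ((1H-1,2,4-triazol-3-yl)methyl)(methyl)amino group, with a 7.1-fold higher number from compound 1 to compound 3 (0.85 log units; beyond the scatter) remaining, so only part of the earlier loss from a 50-fold higher number from compound 1 to compound 2 (1.70 log units; beyond the scatter) is regained. No supporting measurement is available to explain these steps.

The change from compound 2 to compound 3 both places a methyl on the ring and removes one from the amine nitrogen, so the two contributions cannot be separated. Going by these compounds, it also remains open how an ethyl on the tetrazole ring, or a 1,2,3-triazole in its place, would read in this assay.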